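The source may report more compounds than this note shows. Statements on the series, on what has been measured and on what is new or still open speak of the compounds shown alone.

Measured compounds:
- compound 1, `COc1ccc(OC)c(/C=C/c2nnc(Nc3ccc(Cl)cc3)o2)c1`: 17400 nM
- compound 2, `COc1ccc(OC)c(/C=C/C(=O)N/N=C/c2ccc(Cl)cc2)c1`: 52.2 nM

Going by the values given here, in a functional assay on KM12 cells (Homo sapiens) for antiproliferative activity, read by sulforhodamine B assay, with a stated time of 48 h (on this read-out higher numbers stand for weaker inhibition of growth and lower numbers for stronger inhibition of growth), compound 2 gives 52.2 nM and stands at the lower of the two numbers so far; compound 1 gives 17400 nM, and the gap between the two lies well beyond the scatter. Among the compounds with values here, compound 1 and compound 2 differ in more than one place, so the two values show only that the acylhydrazone of compound 2 sits far lower than the oxadiazole of compound 1, not which part of the change carries the difference.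

The next compound is compound 3, `COc1ccc(OC)c(/C=C/C(=O)N/N=C/c2ccccc2)c1`, which keeps the whole of compound 2 except for one change: hydrogen in place of chloro on an aromatic carbon. Within the data shown here, no step of exactly this kind is measured, so the direction has to be expected rather than read off. Within this series, compound 2 gives the low value 52.2 nM with the chloro in place; loss of that group is expected to move the number upward by a modest step, probably beyond the scatter but not greatly so, and a step of about a 2.9-fold higher number from compound 2 to compound 3 (0.46 log units; beyond the scatter) is expected. Compound 3 is therefore estimated at 150 nM, with a range from 40 nM to 600 nM.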

Compound 3, concentration for 50% growth inhibition: 834 nM
Compound 3: the middle estimate sits 5.6-fold (0.75 log units) below what was measured; the measured number lies above the stated range.
By their numbers in this assay, from the lowest: compound 2; then compound 3; then compound 1.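

In this assay, hydrogen in place of chloro on an aromatic carbon, para to a large group, gives a 16-fold higher number from compound 2 to compound 3 (1.20 log units; beyond the scatter). Going by these compounds alone, this is the first one-place comparison, and it shows that the change from 4-chlorophenyl to phenyl, with the rest of compound 2 kept, is enough on its own to move the number well beyond the scatter, so the single chlorine atom at this position weighs heavily in the low value of compound 2. No available measurement accounts for the size of this step, so the result stands as an observation on this pair alone.

Going by these compounds, whether a fluoro, a methyl, a methoxy or an amine at this same position would keep the number close to that of compound 2 or leave it nearer that of compound 3 remains open, as does the outcome of moving the chloro to another carbon of the same ring. Also open, on these data alone, is whether the same change would give a step of similar size on the core of compound 1.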